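Mouse microsome stability: from compound 2 to compound 4

The source may hold more compounds than are shown below. What is called first, only, known or untested is meant among the compounds shown, and "the series" means these compounds.

Measured in an ADME assay on microsomes from liver (Mus musculus) for metabolic stability, with a stated time of 10 min; on this read-out lower numbers stand for a less stable compound and higher numbers for a more stable compound:
- Compound 1 `O=C(O)C1CCC(O)(C(=O)N2CC[C@](c3ccc(C(F)(C(F)(F)F)C(F)(F)F)cc3)(S(=O)(=O)c3ccc(F)cc3)C2)CC1`: 99%; 98% (2 entries)
- Compound 2 `O=C(N1CC[C@](c2ccc(C(F)(C(F)(F)F)C(F)(F)F)cc2)(S(=O)(=O)c2ccc(F)cc2)C1)C12CCC(C(=O)O)(CC1)OC2`: "not determined" (no result reported)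
- Compound 3 `O=C1NC(=O)C2(CCC(C(=O)N3CC[C@](c4ccc(C(F)(C(F)(F)F)C(F)(F)F)cc4)(S(=O)(=O)c4ccc(F)cc4)C3)CC2)N1`: 81%; 82% (2 entries)

Compound 2 has no number to stand on, so its place in this assay is open. Compound 4 `CCC1(C(=O)N2CC[C@](c3ccc(C(F)(C(F)(F)F)C(F)(F)F)cc3)(S(=O)(=O)c3ccc(F)cc3)C2)CCS(=O)(=O)CC1` remains unmeasured. The structural change is a group of 10 heavy atoms (7 carbon, 2 oxygen, 1 sulfur; one six-membered non-aromatic ring with 1 hetero atom) in place of a group of 11 heavy atoms (8 carbon, 3 oxygen; one six-membered non-aromatic ring of carbon only, one six-membered non-aromatic ring with 1 hetero atom), on a carbonyl carbon. In words, 4-ethyl-1,1-dioxothian-4-yl now sits on the carbonyl carbon whose other neighbour is the amide-type nitrogen in a ring.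

Without a value for compound 2, the step cannot be sized from measurement. The working expectation is no step beyond the scatter, on the assumption that compound 2 lies in the range of its two measured relatives. Those relatives both retain most of the material: compound 1 shows 99%; 98% (2 entries) and compound 3 shows 81%; 82% (2 entries). With a new group in place, the lower of these two levels is the more cautious guide, and the downside is left wide.

For compound 4 the expected value is 78%, with an estimated range from 55% to 95%.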

Compound 4, percent of the compound remaining: 0%
Compound 4: middle estimate off by 78 percentage points, on the high side, outside the stated range (below it).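

Among the compounds shown here, compound 2 has no reported result in this assay, so no step to compound 4, which stands at 0%, can be read. The compounds shown leave open what lies behind the result for compound 4, and no measurement here bears on it.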